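This account rests on a few compounds, and the source may have more. Where it says the series, first, only, none or still open, it means among the compounds named here.

Measured in a functional assay on HeLa cells (Homo sapiens) for antiproliferative activity, read by sulforhodamine B assay, with a stated time of 72 h; on this read-out higher numbers stand for weaker inhibition and lower numbers for stronger inhibition:
- compound 1 `N#Cc1ccc(NC(=S)N/N=C/c2ccc3ccccc3n2)cc1`: 20000 nM
- compound 2 `Cc1ccc(NC(=S)N/N=C/c2ccc3ccccc3n2)cc1`: 86000 nM
- compound 3 `Fc1ccc(NC(=S)N/N=C/c2ccc3ccccc3n2)cc1`: 33200 nM

Compound 3 gives 33200 nM, the middle number of the three. It shows a 1.7-fold higher number from compound 1 to compound 3 (0.22 log units; within the scatter), so those two cannot be told apart, but it clearly differs from the weakest compound, with a 2.6-fold lower number from compound 2 to compound 3 (0.41 log units; beyond the scatter).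

Compound 4 `FC(F)(F)c1ccc(NC(=S)N/N=C/c2ccc3ccccc3n2)cc1` follows from compound 3 by one change: trifluoromethyl in place of fluoro on an aromatic carbon. Going by the values given here, no measured compound carries trifluoromethyl, so the guide is the other swaps at this same place. These are a 4.3-fold higher number from compound 1 to compound 2 (0.63 log units; beyond the scatter), together with the two steps above. None is more than modest, so no step beyond the scatter is expected in this assay, and neither direction is favoured. The expected step is a 1.1-fold lower number from compound 3 to compound 4 (0.04 log units; within the scatter). The estimate for compound 4 is 30000 nM, with an expected range of 12000 nM to 80000 nM.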

Compound 4, half-maximal inhibitory concentration: 59100 nM
Compound 4: middle estimate off by 2.0-fold (0.29 log units), on the low side, within the range that was stated.
By their numbers in this assay, from the lowest: compounds 1, 3, 4 and 2 (each within the scatter of the next, the first and the last beyond it).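

Trifluoromethyl cannot be told apart from fluoro in this assay (a 1.8-fold higher number from compound 3 to compound 4 (0.25 log units; within the scatter)) or from methyl (a 1.5-fold lower number from compound 2 to compound 4 (0.16 log units; within the scatter)), but it does stand apart from cyano (a 3.0-fold higher number from compound 1 to compound 4 (0.47 log units; beyond the scatter)). Putting a group of 4 heavy atoms in place of a single fluorine therefore leaves the number within the scatter at this position. Nothing available here explains these steps.

Still open, from the compounds shown here alone, is how an amine, a carboxylic acid or a methoxy group would read at this same place, and whether any group on this ring gives a number far lower than these four.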